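The compounds below may be only part of what the source reports. "The series", "measured", "known", "first", "only" and "open" are said of these compounds alone.

For the measured compounds named here, in a functional assay on HepG2 cells (Homo sapiens) for inhibition, read by MTT assay, with a stated time of 48 h (a higher number here means a weaker inhibitor, a lower number a stronger inhibitor), compound 1 (`COc1cc(-c2nccn3cc(-c4ccc(F)cc4)nc23)cc(OC)c1OC`) gives 217 nM and compound 2 (`COc1cc(-c2nccn3cc(-c4ccccc4)nc23)cc(OC)c1OC`) gives 267 nM as its value, which places compound 2 within the scatter of compound 1, the only other compound measured so far. Compound 3 (`COc1cc(-c2nccn3cc(-c4ccc([N+](=O)[O-])cc4)nc23)cc(OC)c1OC`) is still unmeasured and differs from compound 2 by a single change (nitro in place of hydrogen on an aromatic carbon): nitro in place of hydrogen on an aromatic carbon. Going by the values given here, one measured step bears on this, hydrogen in place of fluoro on an aromatic carbon, and it is small and within the scatter (a 1.2-fold higher number from compound 1 to compound 2 (0.09 log units; within the scatter)). Nitro is a different group from fluoro, and no nitro compound has been measured here, so that step is only a loose guide. No shift beyond the scatter is therefore expected in this assay in either direction, though the uncertainty is wide. The expected step is small (a 1.0-fold higher number from compound 2 to compound 3 (0.02 log units; within the scatter)). Compound 3 is estimated at 280 nM (expected range 90 nM to 900 nM).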

Compound 3, half-maximal inhibitory concentration: > 10000 nM
Compound 3 ended at the assay's limit (the forecaster's own chance of this, stated with the estimate: 3%); middle value at least 35-fold (1.55 log units) away from the limit.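

Compounds 1 and 2 compared only fluoro with hydrogen at this place, para to a large group, and that small swap left open how much the place could tolerate. Nitro shows that it does not accept every group in this assay: the swap from phenyl to 4-nitrophenyl gives an at least 37-fold higher number from compound 2 to compound 3 (1.57 log units; beyond the scatter), and nitro in place of fluoro gives an at least 46-fold higher number from compound 1 to compound 3 (1.66 log units; beyond the scatter). Compound 3, at > 10000 nM, stands at a limit of the assay and not at a number: the limit of > 10000 nM in this assay, at which 1 of the 3 values shown sits.

The three compounds shown cannot say what it is about nitro that matters, or how far the true steps reach past that limit. An amine or a carboxylic acid at this same place, or nitro on another carbon of the ring, would show whether the drop belongs to nitro alone.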